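This account rests on a few compounds, and the source may have more. Where it says the series, first, only, none or still open, it means among the compounds named here.

Working notes on the series. Compound 3 `COc1ccc(/C=N/NC(=S)NC(C)(C)[C@H]2CC=C(C)CC2)cc1` gives 11400 nM in a functional assay on U-251 cells (Homo sapiens) for inhibition, read by sulforhodamine B assay, with a stated time of 48 h (on this read-out lower numbers stand for stronger inhibition of growth and higher numbers for weaker inhibition of growth), the second highest of the three numbers in hand: compound 1 `CC1=CC[C@H](C(C)(C)N=C=S)CC1` gives 29100 nM, and compound 2 `CC1=CC[C@H](C(C)(C)NC(=S)NN)CC1` gives 200 nM. Going by the values given here, the one single-point step measured, a 150-fold lower number from compound 1 to compound 2 (2.16 log units; beyond the scatter), concerns a change on the saturated chain carbon of the core and does not touch the aryl end. Compound 4 `CC1=CC[C@H](C(C)(C)NC(=S)N/N=C/c2cccc(Cl)c2)CC1` differs from compound 3 by 3-chlorophenyl in place of 4-methoxyphenyl on a carbon with a double bond to nitrogen. Among the compounds with values here, no measured step bears on this change, so no step beyond the scatter is expected in this assay for compound 4, with a 1.1-fold lower number from compound 3 to compound 4 (0.06 log units; within the scatter) as the expected step. Compound 4 is therefore estimated at 10000 nM, within 3000 nM to 35000 nM.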

Compound 4, concentration for 50% growth inhibition: 7900 nM
Estimate against measurement, compound 4: 1.3-fold (0.10 log units) above, and the stated range covers the measured number.
By their numbers in this assay, from the lowest: compound 2; then compounds 4 and 3 (each within the scatter of the next); then compound 1.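

On the carbon with a double bond to nitrogen, 3-chlorophenyl in place of 4-methoxyphenyl comes with a 1.4-fold lower number from compound 3 to compound 4 (0.16 log units; within the scatter) in this assay, the first step read at the aryl end of the series. This pair therefore shows no separation between these two aryl groups at this position. Nothing measured on these compounds bears on this result.

Open, going by these compounds, is whether an amine or a carboxylic acid on the aryl ring, or a saturated chain in place of that ring, would change the number. The two groups differ in both substituent and its place on the ring, so neither can be read alone.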